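Lengthening the Nitrogen Substituent in Compound 2

This account rests on a few compounds, and the source may have more. Where it says the series, first, only, none or still open, it means among the compounds named here.

Measured compounds:
compound 1, `CCCn1c(=O)c2nc(C(c3ccccc3)C3CC3)[nH]c2n(CCC)c1=O` — 150 nM in an assay on cell membranes for binding affinity to adenosine receptor A1 (Cavia porcellus); on this read-out lower numbers stand for stronger inhibition and higher numbers for weaker inhibition
compound 2, `CCCn1c(=O)c2c(nc(C(C3CC3)C3CC3)n2C)n(CCC)c1=O` — 7400 nM

Compound 2 gives the higher of the two numbers in this assay; compound 1 gives a far lower number, a gap beyond the scatter. Compound 3, `CCCn1c(=O)c2c(nc(C(C3CC3)C3CC3)n2CC)n(CCC)c1=O`, differs from compound 2 by methyl in place of hydrogen on a saturated chain carbon bound to an aromatic nitrogen. Within the data shown here, no measured pair shows this change, so the size of the step is uncertain. Compound 2 already binds weakly at 7400 nM, and a small further weakening, or no step beyond the scatter, is expected: a 1.4-fold higher number from compound 2 to compound 3 (0.13 log units; within the scatter). Compound 3 is therefore estimated at 10000 nM, within a range from 3000 nM to 40000 nM.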

Compound 3, inhibition constant: 1600 nM
For compound 3 the middle estimate is 6.3-fold (0.80 log units) above the measured one; the measured number lies below the stated range.
By their numbers in this assay, from the lowest: compound 1; then compound 3; then compound 2.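

Methyl in place of hydrogen on a saturated chain carbon bound to an aromatic nitrogen, which turns methyl into ethyl, gives a 4.6-fold lower number from compound 2 to compound 3 (0.67 log units; beyond the scatter) in this assay. Among these compounds, this position therefore responds to a single added carbon, and here the ethyl compound gives the lower number, which the earlier compounds could not show. Nothing shown gives a reason for this step. With a single step at this position, no direction can be claimed for chain length in general. On these data alone, whether a propyl group, a longer chain or a chain ending in an amine would lower the number further remains open.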